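This account rests on a few compounds, and the source may have more. Where it says the series, first, only, none or still open, it means among the compounds named here.

Measured compounds in a physicochemical assay for solubility, with a stated time of 3 days, at pH 2; a lower number here means a less soluble compound, a higher number a more soluble compound:

compound 1, `NC(=O)c1ccc2[nH]c(-c3ccc(OCCCO)cc3)nc2c1`: 185000 nM
compound 2, `NC(=O)c1ccc2[nH]c(-c3ccc(OC4CCNCC4)cc3)nc2c1`: "not determined" (no result reported)
compound 3, `COc1ccc(CN2CCCCC2CCOc2ccc(-c3nc4cc(C(N)=O)ccc4[nH]3)cc2)cc1`: > 400000 nM

For the measured compounds named here, compound 1 is the only compound with a plain number. Compound 2 has no result. For compound 3 the entry is the limit of > 400000 nM in this assay, at which 1 of the 3 values shown sits, a limit of the assay and not a number.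

Compound 4, `CC(=O)N1CCC(CCOc2ccc(-c3nc4cc(C(N)=O)ccc4[nH]3)cc2)CC1`, is not yet measured. It differs from compound 1 in one place: 1-acetylpiperidin-4-yl in place of hydroxymethyl on a saturated chain carbon, two bonds along the chain from an oxygen on an aromatic ring. Going by the values given here, no pair of measured compounds shows what such a change does in this assay, so the expectation rests on compound 1 with 185000 nM. The step from compound 1 to compound 4 is expected to be a modest fall, close to the scatter, a 1.9-fold lower number from compound 1 to compound 4 (0.27 log units; within the scatter). Compound 4 is therefore expected to give 100000 nM, between 30000 nM and 300000 nM.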

Compound 4, solubility: 87000 nM
Compound 4: the middle estimate sits 1.1-fold (0.06 log units) above what was measured, within the range that was stated.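

In this assay, for the compounds shown here, 1-acetylpiperidin-4-yl in place of hydroxymethyl on this saturated chain carbon gives a 2.1-fold lower number from compound 1 to compound 4 (0.33 log units; beyond the scatter), the first step that can be read at this position. A much larger group, with a six-membered non-aromatic ring and no hydrogen-bond donor, therefore goes with only a modest step here. Nothing shown gives a cause for this step.

The compounds shown do not separate the part played by the ring from that of the acetyl. On these data alone, how a carboxylic acid or a longer chain would read at this place also remains open.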